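A few compounds are considered here, and "the series" means these few. Any claim that something is new, unique, unknown or untested is made for them only; others in the source may bear on it.

Measured compounds so far:
- compound 1 `Cc1nc(N)c2ncn(C3CN(C(=O)c4ccn(CC5CCN(C6CCCCCC6)CC5)c4)C3)c2n1`: 4000 nM
- compound 2 `Cc1nc(N)c2ncn(C3(C)CN(C(=O)c4cc(CN5CCN(C6CCCCCC6)CC5)n(C)n4)C3)c2n1`: 3000 nM

Of the compounds shown here, two have been measured in an assay on Sf9 cells for inhibition of N-lysine methyltransferase SMYD2 (Homo sapiens), read by scintillation proximity assay, with a stated time of 120 min, in the presence of a further agent that is not named here; a lower number here means a stronger inhibitor, a higher number a weaker inhibitor. Compound 1 gives 4000 nM, the higher of the two numbers, and compound 2 gives 3000 nM; the gap between them lies within the scatter, so neither can be called the stronger inhibitor. Within the data shown here, no pair of measured compounds differing in a single place is available, so no step of known size can guide the next comparison.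

Compound 3 `Cc1nc(N)c2ncn(C3CN(C(=O)c4ccn(CC5CCN(C6C=CCCCC6)CC5)c4)C3)c2n1` has not yet been measured. Compared with compound 1 it carries cyclohept-2-en-1-yl in place of cycloheptyl on an amine nitrogen in a ring. One seven-membered carbon ring gives way to another that has a single double bond outside aromatic rings; nothing in the measured data shows how such a swap plays out. In this assay the author expects no step beyond the scatter, the expected step being no change at the digits printed from compound 1 to compound 3 (within the scatter). Compound 3 is therefore estimated at 4000 nM, within a range from 1500 nM to 10000 nM.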

Compound 3, half-maximal inhibitory concentration: 23 nM
Compound 3: middle estimate off by 170-fold (2.24 log units), on the high side; the whole stated range lies above it.
By their numbers in this assay, from the lowest: compound 3; then compounds 2 and 1 (each within the scatter of the next).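

In this assay, one double bond in the seven-membered carbon ring makes a large difference: cyclohept-2-en-1-yl in place of cycloheptyl gives a 170-fold lower number from compound 1 to compound 3 (2.24 log units; beyond the scatter), while the heavy-atom count, the absence of hydrogen-bond donors and acceptors, and the lack of net charge all stay the same. Among these compounds, this place, on an amine nitrogen in a ring, is therefore highly sensitive to a small change in the ring it carries, which the earlier compounds could not reveal. Nothing available explains why this change has so large an effect.

The compounds shown leave open whether the double bond must sit where it does, as a cyclohept-3-en-1-yl group would test, or whether a smaller ring such as cyclohex-2-en-1-yl would serve as well. From the compounds shown here alone, it also remains open whether the same swap on compound 2 would bring a step of similar size.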